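Sulfonamide Series: Replacing Naphthyl with Chloro

The source may report more compounds than this note shows. Statements on the series, on what has been measured and on what is new or still open speak of the compounds shown alone.

Compound 1, `COc1ccc(-c2cccc(S(=O)(=O)N3CCC(N4CCC(C)CC4)CC3)c2)cc1`: in a functional assay on DLD-1 cells (Homo sapiens) for antiproliferative activity, read by CellTiter-Glo, with a stated time of 72 h (a lower number here means a stronger inhibitor, a higher number a weaker inhibitor), compound 1 gives 23 nM.
Compound 2, `Cc1ccc(S(=O)(=O)N2CCC(N3CCC(C)CC3)CC2)cc1C`: compound 2 gives 24 nM.
Compound 3, `CC1CCN(C2CCN(S(=O)(=O)c3cccc(-c4ccc5ccccc5c4)c3)CC2)CC1`: compound 3 gives 2 nM.

Compound 3 holds the lowest number of the three, separated from both compound 1 and compound 2 by steps beyond the scatter. Compound 4, `CC1CCN(C2CCN(S(=O)(=O)c3cccc(Cl)c3)CC2)CC1`, differs from compound 3 by chloro in place of naphthalen-2-yl on an aromatic carbon. For the measured compounds named here, the one measured step that bears on this change is a 12-fold lower number from compound 1 to compound 3 (1.06 log units; beyond the scatter), in which the naphthalen-2-yl group entered; compound 4 removes that group altogether, leaving only a single chlorine there. A step in the opposite direction, beyond the scatter, is therefore expected in this assay: a 75-fold higher number from compound 3 to compound 4 (1.88 log units; beyond the scatter). Compound 4 is estimated at 150 nM, with a range from 40 nM to 600 nM.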

Compound 4, half-maximal inhibitory concentration: > 5000 nM
Compound 4 ended at the assay's limit (the forecaster's own chance of this, stated with the estimate: 5%); middle value at least 33-fold (1.52 log units) from the limit.
By their numbers in this assay, from the lowest: compound 3; then compounds 1 and 2 (each within the scatter of the next). At a limit, above all of these: compound 4.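

In this assay compound 4 gives > 5000 nM which is a limit of the assay and not a number. A lone chloro at this place falls far short of either aromatic group: the compounds show an at least 2500-fold higher number from compound 3 to compound 4 (3.39 log units; beyond the scatter) and an at least 210-fold higher number from compound 1 to compound 4 (2.33 log units; beyond the scatter) as large steps. Compound 2 carries two methyl groups and no second aromatic ring, yet the compounds also show an at least 200-fold higher number from compound 2 to compound 4 (2.31 log units; beyond the scatter) so losing that ring does not alone account for the fall.

As far as these compounds go, whether a methyl group or an amine at this place would hold activity where chloro does not stays open. So does whether a second substituent on the 3-chlorophenyl ring would restore it.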